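The compounds below may be only part of what the source reports. "The series", "measured", "known", "first", "only" and "open" are said of these compounds alone.

In a functional assay on HCT-116 cells (Homo sapiens) for cytotoxicity, read by MTT assay, with a stated time of 48 h (a higher number here means a weaker inhibitor of growth, a lower number a stronger inhibitor of growth), compound 1 `Clc1cc2nc(-c3ccccc3Cl)[nH]c2cc1Cl` gives 23000 nM and compound 2 `FC(F)(F)c1nc2cc(Cl)c(Cl)cc2n1Cc1ccccc1` gives 8600 nM. Compound 3 `FC(F)(F)c1cccc(Cn2c(C(F)(F)F)nc3cc(Cl)c(Cl)cc32)c1` gives 50500 nM, the highest of the three numbers. Compound 4 `O=[N+]([O-])c1cccc(Cn2c(C(F)(F)F)nc3cc(Cl)c(Cl)cc32)c1` carries nitro in place of trifluoromethyl on an aromatic carbon, meta to a large group: nitro in place of trifluoromethyl on an aromatic carbon. Going by the values given here, one measured step bears on this change: a 5.9-fold higher number from compound 2 to compound 3 (0.77 log units; beyond the scatter), a modest rise when trifluoromethyl took the place of hydrogen on an aromatic carbon. Among the compounds with values here, no measured compound carries nitro, so the data do not show how it compares. A small move toward a lower number in this assay is expected, smaller than that rise. The estimated change is a 2.0-fold lower number from compound 3 to compound 4 (0.31 log units; beyond the scatter). For compound 4 the expected value is 25000 nM, with an estimated range from 9000 nM to 60000 nM.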

Compound 4, concentration for 50% growth inhibition: 22800 nM
Compound 4: the middle estimate sits 1.1-fold (0.04 log units) above what was measured, within the range that was stated.
By their numbers in this assay, from the lowest: compound 2; then compounds 4 and 1 (each within the scatter of the next); then compound 3.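

In this assay, the aromatic carbon meta to a large group responds to which group it carries, not merely to whether a group is present: there is a 2.2-fold lower number from compound 3 to compound 4 (0.35 log units; beyond the scatter) when nitro replaces trifluoromethyl. Nitro still does not match hydrogen, with a 2.7-fold higher number from compound 2 to compound 4 (0.42 log units; beyond the scatter), so both groups shown here give higher numbers than hydrogen. Nothing available accounts for these differences.

The compounds shown leave open whether an amine or a carboxylic acid on this carbon would give a number as low as hydrogen does. They also leave open whether nitro would act alike on another carbon of this ring.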